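Fluorine for Chlorine on the Anilide Ring

A few compounds are considered here, and "the series" means these few. Any claim that something is new, unique, unknown or untested is made for them only; others in the source may bear on it.

Compound 3 `COc1ccc2c(=O)c(/C=C/C(=O)Nc3ccc(Cl)cc3)coc2c1` gives 272000 nM in an ADME assay on HepG2 2.2.15 cells (Homo sapiens) for cytotoxicity, read by MTT assay, with stated times of 48 h and 9 days (on this read-out lower numbers stand for higher toxicity in this test and higher numbers for lower toxicity in this test), the second highest of the three numbers measured. Compound 1 `COc1ccc2c(=O)c(/C=C/C(=O)NCc3ccccc3)coc2c1` gives 376000 nM in this assay, a value within the scatter of that of compound 3, so no order between the two can be read. Compound 2 `COc1ccc2c(=O)c(/C=C/C(=O)Nc3ccccc3C)coc2c1` gives 59700 nM in this assay, and the step of a 4.6-fold higher number from compound 2 to compound 3 (0.66 log units; beyond the scatter) is modest but beyond the scatter, as is a 6.3-fold lower number from compound 1 to compound 2 (0.80 log units; beyond the scatter). Compound 4 `COc1ccc2c(=O)c(/C=C/C(=O)Nc3ccc(F)cc3)coc2c1` differs from compound 3 by fluoro in place of chloro on an aromatic carbon. For the measured compounds named here, no measured step exchanges one halogen for another; the two steps beyond the scatter concern whole groups on the amide-type nitrogen, while a 1.4-fold lower number from compound 1 to compound 3 (0.14 log units; within the scatter) stays within it. Compound 4 is therefore expected to show no step beyond the scatter, a 1.0-fold higher number from compound 3 to compound 4 (0.01 log units; within the scatter). Compound 4 is estimated at 280000 nM, within 120000 nM to 600000 nM.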

Compound 4, half-maximal cytotoxic concentration: 743000 nM
Estimate against measurement, compound 4: 2.7-fold (0.42 log units) below, and the stated range ends below it.
By their numbers in this assay, from the lowest: compound 2; then compounds 3, 1 and 4 (each within the scatter of the next, the first and the last beyond it).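

In this assay, the exchange of a single halogen on the aromatic carbon para to a large group gives a step beyond the scatter (a 2.7-fold higher number from compound 3 to compound 4 (0.44 log units; beyond the scatter)), so this position responds to a one-atom change, which no earlier step had shown. The wider step (a 12-fold higher number from compound 2 to compound 4 (1.10 log units; beyond the scatter)) is the largest seen, while the step from the benzyl compound (a 2.0-fold higher number from compound 1 to compound 4 (0.30 log units; within the scatter)) stays within the scatter. Nothing available explains the halogen exchange.

As far as these compounds go, how hydrogen, bromo or methoxy would read at this place remains open. So does whether fluoro in place of chloro gives the same step elsewhere on the ring.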